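Acylating the Amine of a Threonine Octadecylamide

A few compounds are considered here, and "the series" means these few. Any claim that something is new, unique, unknown or untested is made for them only; others in the source may bear on it.

Compound 1 `CCCCCCCCCCCCCCCCCCNC(=O)[C@@H](N)[C@@H](C)O` is a threonine amide carrying a long saturated chain. In a functional assay on A-431 cells (Homo sapiens) for cytotoxicity, read by MTT assay, with a stated time of 48 h (a lower number here means a stronger inhibitor, a higher number a weaker inhibitor), compound 1 gives 21300 nM. Compound 3 `CCCCCCCCCCCCCCNC(=O)[C@@H](NC(=O)c1nccc2ccccc12)[C@@H](C)O` gives 23000 nM, within the scatter of compound 1, while compound 2 `CCCCCCCCCCCCNC(=O)[C@@H](NC(=O)c1cc2ccccc2n1C)[C@@H](C)O` gives 169000 nM, a gap beyond the scatter. Compound 4 `CCCCCCCCCCCCCCCCCCNC(=O)[C@@H](NC(=O)/C=C/c1ccccc1)[C@@H](C)O` is the next compound on this path, and it differs from compound 1 in one place: (2-phenylethenyl)carbonyl in place of hydrogen on an amine nitrogen. Both acylated compounds already measured sit at or above compound 1, so no step beyond the scatter, or at most a modest move toward a higher number, is expected for a 1.6-fold higher number from compound 1 to compound 4 (0.22 log units; within the scatter). Compound 4 is therefore estimated at 35000 nM, with a range from 9000 nM to 140000 nM.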

Compound 4, half-maximal inhibitory concentration: 177000 nM
The estimate for compound 4 lay 5.1-fold (0.70 log units) below the measured number; the measured number lies above the stated range.
By their numbers in this assay, from the lowest: compounds 1 and 3 (each within the scatter of the next); then compounds 2 and 4 (each within the scatter of the next).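

In this assay, (2-phenylethenyl)carbonyl in place of hydrogen on the amine nitrogen gives an 8.3-fold higher number from compound 1 to compound 4 (0.92 log units; beyond the scatter), which is beyond the usual scatter. Going by these compounds alone, this is the first reading of acylation at this position with the chain held fixed, since compound 2 and compound 3 differ from compound 1 in chain length as well as on the nitrogen. Nothing given here accounts for the step. As far as these compounds go, whether a small acetyl group on the same nitrogen would produce a similar step remains open. So does whether (2-phenylethenyl)carbonyl would have the same effect on a shorter chain.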